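Aryl swap on the fused core of a fatty acid receptor series

The source may report more compounds than this note shows. Statements on the series, on what has been measured and on what is new or still open speak of the compounds shown alone.

Measured in an assay on isolated protein for agonist activity at Free fatty acid receptor 1 (Homo sapiens); on this read-out lower numbers stand for an effect already at smaller amounts and higher numbers for an effect only at larger amounts of compound:
- compound 1 `CC#CC(CC(=O)O)c1ccc(OCc2ccc3nc(-c4ccc(C5CCCCC5)cc4)cn3c2)cc1`: 417 nM
- compound 2 `CC#CC(CC(=O)O)c1ccc(OCc2ccn3cc(-c4ccccc4C)nc3c2)cc1`: 459 nM

Compound 1 stands at the lowest of the two numbers, yet compound 2 sits within the usual scatter of it, so no order between the two is claimed. Compound 3 `CC#CC(CC(=O)O)c1ccc(OCc2ccc3nc(-c4ccccc4F)cn3c2)cc1` differs from compound 1 by 2-fluorophenyl in place of 4-cyclohexylphenyl on an aromatic carbon. Among the compounds with values here, no step between measured compounds covers this change, so the expectation rests only on the closeness of compound 1 and compound 2, which carry different aryl groups yet give nearly the same number. In this assay compound 3 is expected to land near compound 1, with a modest weakening allowed; the expected step is a 1.6-fold higher number from compound 1 to compound 3 (0.19 log units; within the scatter). Compound 3 is estimated at 650 nM, with a range of 250 nM to 1700 nM.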

Compound 3, half-maximal effective concentration: 583 nM
Compound 3: the middle estimate sits 1.1-fold (0.05 log units) above what was measured; measured number inside the range.
By their numbers in this assay, from the lowest: compounds 1, 2 and 3 (each within the scatter of the next).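

On the aromatic carbon of the five-membered ring, 2-fluorophenyl in place of 4-cyclohexylphenyl gives a 1.4-fold higher number from compound 1 to compound 3 (0.15 log units; within the scatter) in this assay, a step within the scatter. This position therefore keeps its number in this pair without the cyclohexane ring, and the pair shows no sign that the ring's bulk is needed. Nothing measured explains this tolerance. Still open, going by these compounds, is whether unsubstituted phenyl at this carbon gives a similar number, which would test the role of the fluorine. Also open, on these data alone, is whether an aryl group is needed at all, which an amine such as morpholine at this carbon could test.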